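Thiophene-to-tolyl exchange on the pendant aryl of compound 3

The compounds below may be only part of what the source reports. "The series", "measured", "known", "first", "only" and "open" are said of these compounds alone.

Going by the values given here, compound 3 `CC(C)C[C@H](N)CN(C(=O)[C@@H]1C[C@H]1c1ccccc1)c1ccc(-c2ccsc2)cc1` is the weakest of the three measured members: in a functional assay for agonist activity at G protein-coupled receptor 88 (Homo sapiens), read by HTRF and cAMP accumulation (a higher number here means that more compound is needed for the effect, a lower number that less compound is needed), compound 3 gives 1200 nM, the highest number of the set. Compound 1 `CC[C@H](C)[C@@H](CN(C(=O)[C@@H]1C[C@H]1c1ccccc1)c1ccc(-c2ccccc2)cc1)NC(C)=O` gives 5.8 nM in this assay, and compound 2 `CC[C@@H](C)[C@H](N)CN(C(=O)[C@@H]1C[C@H]1c1ccccc1)c1ccc(-c2ccccc2)cc1` gives 1.4 nM, so compound 3 sits far above both. Among the compounds with values here, the only single-point step measured, a 4.1-fold lower number from compound 1 to compound 2 (0.62 log units; beyond the scatter), concerns the side chain, not the pendant aryl. Within the data shown here, compound 3 differs from compound 2 in two places at once, the side chain and the aryl, so the two values show only that the combined change raises the number sharply; the share of each cannot be separated.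

Compound 4 `Cc1ccc(-c2ccc(N(C[C@@H](N)CC(C)C)C(=O)[C@@H]3C[C@H]3c3ccccc3)cc2)cc1` carries 4-methylphenyl in place of thiophen-3-yl on an aromatic carbon, at the position described as para to a large group. Among the measured compounds shown here, no measured step tracks this change. The two measured compounds with a phenyl at this position both give low numbers, which suggests that moving from thiophen-3-yl to a six-membered carbon-only ring would lower the number, but the side-chain difference between compound 3 and compound 2 leaves this uncertain. Compound 4 is therefore expected to show an 8.0-fold lower number from compound 3 to compound 4 (0.90 log units; beyond the scatter) in this assay, an estimate of 150 nM with a range from 15 nM to 1500 nM.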

Compound 4, half-maximal effective concentration: 360 nM
The estimate for compound 4 lay 2.4-fold (0.38 log units) below the measured number; low and high end bracket the measured number.
By their numbers in this assay, from the lowest: compound 2; then compound 1; then compound 4; then compound 3.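

In this assay, 4-methylphenyl in place of thiophen-3-yl, on an aromatic carbon para to a large group, gives a 3.3-fold lower number from compound 3 to compound 4 (0.52 log units; beyond the scatter). Going by these compounds alone, this is the first step that reads the pendant aryl on its own, with the side chain held constant, and it shows that this position responds to the exchange, by a modest step beyond the scatter. No measurement at hand explains the shift at this position.

The step replaces a five-membered aromatic ring with 1 hetero atom by a six-membered aromatic ring of carbon only and adds a methyl group at the same time, so the compounds shown do not separate the share of the ring from that of the methyl group. Also open, going by these compounds, are what a 4-chlorophenyl or 4-methoxyphenyl group would give at this position, and whether a step of this size would carry over to the 1-amino-2-methylbutyl side chain of compound 2.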